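Does a longer chain change compound 3's activity?

The source may hold more compounds than are shown below. What is called first, only, known or untested is meant among the compounds shown, and "the series" means these compounds.

Compound 1 `COc1ccc(N(C)c2ccnc(Cl)n2)cc1OCCCBr`: 307 nM
Compound 2 `COc1ccc(N(C)c2ccnc(Cl)n2)cc1OCCCCBr`: 307 nM
Compound 3 `COc1ccc(N(C)c2ccnc(Cl)n2)cc1OCC[Se]C#N`: 436 nM

All three values come from a functional assay on HeLa cells (Homo sapiens) for antiproliferative activity, read by MTT assay, with a stated time of 48 h; a lower number here means a stronger inhibitor, a higher number a weaker inhibitor. Compound 3 stands within the scatter of both others, as a 1.4-fold higher number from compound 1 to compound 3 (0.15 log units; within the scatter) and a 1.4-fold higher number from compound 2 to compound 3 (0.15 log units; within the scatter) show. Compound 4 `COc1ccc(N(C)c2ccnc(Cl)n2)cc1OCCCC[Se]C#N` carries one change, (a group of 5 heavy atoms (3 carbon, 1 nitrogen, 1 selenium; no ring) in place of a group of 3 heavy atoms (1 carbon, 1 nitrogen, 1 selenium; no ring), on a saturated chain carbon, two bonds along the chain from an oxygen on an aromatic ring), on a saturated chain carbon, two bonds along the chain from an oxygen on an aromatic ring. The nearest measured step swaps bromo for bromomethyl on a chain, and it shows no change at the digits printed from compound 1 to compound 2 (within the scatter). Within the data shown here, this one step is the only guide, so no shift beyond the scatter is expected in this assay, in either direction. The estimated step is a 1.0-fold lower number from compound 3 to compound 4 (0.02 log units; within the scatter). For compound 4 the estimated value is 420 nM, with an expected range of 190 nM to 900 nM.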

Compound 4, half-maximal inhibitory concentration: > 10000 nM
Compound 4 was reported as a limit; the forecaster's own chance of this, stated with the estimate: 3%; at least 23-fold (1.37 log units) between middle value and limit.
By their numbers in this assay, from the lowest: compounds 1, 2 and 3 (each within the scatter of the next). At a limit, above all of these: compound 4.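

With bromine at the chain end, lengthening gives no change at the digits printed from compound 1 to compound 2 (within the scatter), but with the selenium and nitrile end it gives an at least 22-fold higher number from compound 3 to compound 4 (1.36 log units; beyond the scatter). The effect of chain length at this position therefore depends on the end group, and compound 4 also stands apart from both bromine compounds, with an at least 32-fold higher number from compound 2 to compound 4 (1.51 log units; beyond the scatter) and an at least 32-fold higher number from compound 1 to compound 4 (1.51 log units; beyond the scatter). The result for compound 4 is a limit, not a number: the limit of > 10000 nM in this assay, at which 1 of the 4 values shown sits.

The compounds shown leave open whether a chain of intermediate length with the same end group stays near compound 3. From the compounds shown here alone, whether an amine at the chain end would follow bromine or selenium also remains unknown.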